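Swapping Chloro for Phenyl at the Assay Limit

The source may report more compounds than this note shows. Statements on the series, on what has been measured and on what is new or still open speak of the compounds shown alone.

Compound 1 `COC(=O)c1c[nH]c2ccccc2c1=O` gives > 20000 nM
Compound 2 `CCOc1ccc2[nH]cc(C(=O)OC)c(=O)c2c1` gives > 20000 nM
Compound 3 `COC(=O)c1c[nH]c2ccc(Cl)cc2c1=O` gives > 20000 nM

These three results come from an ADME assay on J774 cells (Mus musculus) for cytotoxicity (a higher number here means that more compound is needed for the effect, a lower number that less compound is needed), and each is a limit, not a number. Compound 3 stands at > 20000 nM, which is also a limit. The set shows (the limit of > 20000 nM in this assay, at which 3 of the 3 values shown sit). Compound 4 `COC(=O)c1c[nH]c2ccc(-c3ccccc3)cc2c1=O` has phenyl in place of chloro on an aromatic carbon. Among the compounds with values here, the steps that bear on this change are a step that the two limits leave unreadable from compound 1 to compound 3 and a step that the two limits leave unreadable from compound 2 to compound 3. Neither has a size that can be read, so they support no expected direction and no expected step beyond the scatter in this assay. The expected step is a number no higher from compound 3 to compound 4 (the limit leaves the size open). For compound 4 the estimated value is 20000 nM, with an expected range from 8000 nM to 40000 nM.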

Compound 4, half-maximal effective concentration: > 20000 nM
Compound 4: no number, only a limit; the forecaster's own chance of this, stated with the estimate: 70%; the middle value lies on the limit itself.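

In this assay compound 4 gives > 20000 nM, a limit and not a number, and its steps from compound 1, compound 2 and compound 3 cannot be read. The compounds shown leave open what concentration produces cytotoxicity and whether any of these groups alters it: the limit of > 20000 nM in this assay, at which 4 of the 4 values shown sit.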